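Moving the carboxylic acid on the ether-linked aryl ring

The source may report more compounds than this note shows. Statements on the series, on what has been measured and on what is new or still open speak of the compounds shown alone.

Measured compounds:
compound 1 `Cc1cc(C(=O)O)ccc1OCCCCOc1ccc(C(=O)CC(C)C)c(O)c1C` gives 192 nM
compound 2 `COc1cc(C(=O)O)ccc1OCCCCOc1ccc(C(=O)CC(C)C)c(O)c1C` gives 40 nM
compound 3 `Cc1c(OCCCCOc2ccc(C(=O)O)cc2)ccc(C(=O)CC(C)C)c1O` gives 122 nM

In an assay on HEK293 cells for positive allosteric modulation of metabotropic glutamate receptor 2 (Rattus norvegicus), read by thallium flux, with a stated time of 2.5 min (on this read-out lower numbers stand for an effect already at smaller amounts and higher numbers for an effect only at larger amounts of compound), compound 3 stands second highest of the three numbers. Its nearest neighbour is compound 1, whose number is higher by a margin within the scatter, as a 1.6-fold lower number from compound 1 to compound 3 (0.20 log units; within the scatter) shows in the other direction; its furthest is compound 2, and the step of a 3.1-fold higher number from compound 2 to compound 3 (0.48 log units; beyond the scatter) lies beyond the scatter.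

Compound 4 `Cc1c(OCCCCOc2cccc(C(=O)O)c2)ccc(C(=O)CC(C)C)c1O` is obtained from compound 3 by the change (3-carboxyphenyl in place of 4-carboxyphenyl on an oxygen on a saturated carbon). The measured steps concern a substituent on that same ring: a 4.8-fold lower number from compound 1 to compound 2 (0.68 log units; beyond the scatter) and a 1.6-fold lower number from compound 1 to compound 3 (0.20 log units; within the scatter). Among the measured compounds shown here, none of them swaps one carboxyphenyl group for another, so no measured step bears directly on this change, and the data give no guide to its direction. Since the ring itself and its linkage are unchanged, the expected step of a 2.0-fold higher number from compound 3 to compound 4 (0.31 log units; beyond the scatter) is therefore set small and cautious, with a wide range to reflect the lack of a precedent. On this basis compound 4 is expected to give 250 nM, with an estimated range from 70 nM to 900 nM.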

Compound 4, half-maximal effective concentration: 222 nM
Compound 4: middle estimate off by 1.1-fold (0.05 log units), on the high side; measured number inside the range.
By their numbers in this assay, from the lowest: compound 2; then compounds 3, 1 and 4 (each within the scatter of the next).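

With 3-carboxyphenyl in place of 4-carboxyphenyl on an oxygen on a saturated carbon, the result is a 1.8-fold higher number from compound 3 to compound 4 (0.26 log units; within the scatter), so in this assay these two placements of the carboxylic acid cannot be told apart. The earlier steps shown here varied only a substituent on this ring, whereas this one varies where the acid itself sits, and the value stays just as close to that of the methyl-bearing compound, with a 1.2-fold higher number from compound 1 to compound 4 (0.06 log units; within the scatter). Among the compounds shown, then, the placement of the acid on this ring gives no separation beyond the scatter, though that rests on this single pair, and nothing given here offers an explanation for the result.

The compounds shown leave open whether a methoxy group, which accompanies the value of compound 2 at 40 nM, would give a similar step on the 3-carboxyphenyl ring, as that step is known only with the acid placed as in compound 2. They also leave open whether a tetrazole or a primary amide could stand in place of the carboxylic acid on this ring, and what a longer chain would do to either placement.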